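A smaller ring on the shared core

This account rests on a few compounds, and the source may have more. Where it says the series, first, only, none or still open, it means among the compounds named here.

In a functional assay on A2780 cells (Homo sapiens) for inhibition (on this read-out higher numbers stand for weaker inhibition and lower numbers for stronger inhibition), compound 1 `CC(C(=O)Nc1cc(C2CC2)[nH]n1)c1ccc(N2C(=O)CCC2C)cc1` gives 6400 nM and compound 2 `CC(C(=O)Nc1cc(C2CC2)[nH]n1)c1ccc(N2CCC(C(N)=O)C2=O)cc1` gives 5710 nM so the two stand level within the scatter. Within the data shown here, only one measured step bears on the next change: a 1.1-fold lower number from compound 1 to compound 2 (0.05 log units; within the scatter) came with a larger group on the same aromatic carbon and did not move the number beyond the scatter. Compound 3 `CC(C(=O)Nc1cc(C2CC2)[nH]n1)c1ccc(N2CCNC2=O)cc1` carries a 2-oxoimidazolidin-1-yl group para to a large group, and the change reads a group of 6 heavy atoms (3 carbon, 2 nitrogen, 1 oxygen; one five-membered non-aromatic ring with 2 hetero atoms) in place of a group of 9 heavy atoms (5 carbon, 2 nitrogen, 2 oxygen; one five-membered non-aromatic ring with 1 hetero atom), on an aromatic carbon in full. Among the measured compounds shown here, no measured compound carries this group, so the range stays wide. For the measured compounds named here, with only that small step as a guide, no shift beyond the scatter is expected in this assay and the estimated move is a 1.1-fold lower number from compound 2 to compound 3 (0.06 log units; within the scatter) at most loosely. Compound 3 is expected at about 5000 nM with an estimated range from 1800 nM to 14000 nM in this read-out.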

Compound 3, half-maximal inhibitory concentration: 2250 nM
Beside the measured number, compound 3's estimate is 2.2-fold (0.35 log units) above it; measured number inside the range.
By their numbers in this assay, from the lowest: compound 3; then compounds 2 and 1 (each within the scatter of the next).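

At this place on the aromatic carbon, para to a large group, the 2-oxoimidazolidin-1-yl group brings the first shift beyond the scatter in this assay. The shift is modest, with a 2.5-fold lower number from compound 2 to compound 3 (0.40 log units; beyond the scatter) and a 2.8-fold lower number from compound 1 to compound 3 (0.45 log units; beyond the scatter), whereas a 1.1-fold lower number from compound 1 to compound 2 (0.05 log units; within the scatter) showed that the two groups with one hetero atom in the ring stand level despite their different sizes. No measurement shown here accounts for the difference.

The compounds shown leave open whether the lower number goes with the second ring nitrogen or with the smaller group of 6 heavy atoms. Also open, going by these compounds, is how a methyl group on the free ring nitrogen of the 2-oxoimidazolidin-1-yl group, or an open-chain urea at the same place, would read.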